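The compounds below may be only part of what the source reports. "The series", "measured", "known", "first", "only" and "open" are said of these compounds alone.

Measured in a functional assay on HeLa S3 cells (Homo sapiens) for cytotoxicity, read by XTT assay, with a stated time of 3 days; a lower number here means a stronger inhibitor, a higher number a weaker inhibitor:
compound 1 `OC[C@H]1O[C@@H](n2cc(F)c3c(-c4cccs4)ncnc32)[C@H](O)[C@@H]1O`: 4300 nM
compound 2 `OC[C@H]1O[C@@H](n2cc(F)c3c(-c4ccc[nH]4)ncnc32)[C@H](O)[C@@H]1O`: 230 nM

Of these two, compound 2 has the lower number, and so is the stronger inhibitor in this assay. The next compound to consider is compound 3 `OC[C@H]1O[C@@H](n2cc(F)c3c(-c4ccsc4)ncnc32)[C@H](O)[C@@H]1O`, which has thiophen-3-yl in place of 1H-pyrrol-2-yl on an aromatic carbon.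

Within the data shown here, one measured step bears on this change: a 19-fold lower number from compound 1 to compound 2 (1.27 log units; beyond the scatter). This large step came with 1H-pyrrol-2-yl replacing thiophen-2-yl. Compound 3 gives up the 1H-pyrrol-2-yl for another thiophene attachment, so much of that step is expected to be undone, moving the number upward. Among the measured compounds shown here, no measurement yet compares thiophen-3-yl directly with thiophen-2-yl, which leaves the size uncertain. The expected change is a 6.5-fold higher number from compound 2 to compound 3 (0.81 log units; beyond the scatter). For compound 3 the estimated value is 1500 nM, with an expected range of 400 nM to 5000 nM.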

Compound 3, half-maximal inhibitory concentration: 210 nM
Compound 3: middle estimate off by 7.1-fold (0.85 log units), on the high side; the measured number lies below the stated range.
By their numbers in this assay, from the lowest: compounds 3 and 2 (each within the scatter of the next); then compound 1.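

In this assay, the step is a 1.1-fold lower number from compound 2 to compound 3 (0.04 log units; within the scatter), so at this aromatic carbon, thiophen-3-yl, with no hydrogen-bond donor, serves as well as 1H-pyrrol-2-yl, which has one. The large difference in this set instead follows the point of attachment of the thiophene, with thiophen-3-yl in place of thiophen-2-yl giving a 20-fold lower number from compound 1 to compound 3 (1.31 log units; beyond the scatter), so a hydrogen-bond donor on the group is not required for the lower number seen in compound 2. Nothing at hand gives a reason why the two thiophene attachments differ so much.

Going by these compounds, it remains open whether furan-3-yl, furan-2-yl or phenyl at this carbon would give a number close to that of compound 3 or to that of compound 1. Whether a small group such as an amine or a methyl group could replace the ring is also unresolved.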